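Bile acid receptor series: acid to hydroxyethoxy on compound 2

The compounds below may be only part of what the source reports. "The series", "measured", "known", "first", "only" and "open" are said of these compounds alone.

Measured so far:
compound 1 `Cc1nc(OCc2c(-c3c(Cl)cccc3Cl)noc2C(C)C)ccc1N(C)C(=O)c1ccc(C(=O)O)cc1` — 365 nM
compound 2 `CC(C)c1onc(-c2c(Cl)cccc2Cl)c1COc1ccc(N(C)Cc2ccc(CCC(=O)O)cc2)c(C(F)(F)F)n1` — 17 nM

In an assay on isolated protein for agonist activity at Bile acid receptor (Homo sapiens), read by FRET (on this read-out higher numbers stand for an effect only at larger amounts of compound and lower numbers for an effect already at smaller amounts), compound 2 gives the lowest number of the two measured, with compound 1 as its nearest neighbour, a gap well beyond the scatter. Compound 3 `CC(C)c1onc(-c2c(Cl)cccc2Cl)c1COc1ccc(N(C)Cc2ccc(OCCO)cc2)c(C(F)(F)F)n1` is not yet measured. It differs from compound 2 in one place: 2-hydroxyethoxy in place of 2-carboxyethyl on an aromatic carbon. Among the measured compounds shown here, no measured pair shows this change. The expectation for this assay is a step to a higher number, of moderate size, beyond the scatter: a 6.5-fold higher number from compound 2 to compound 3 (0.81 log units; beyond the scatter). Compound 3 is therefore estimated at 110 nM, with a range from 25 nM to 600 nM.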

Compound 3, half-maximal effective concentration: 164 nM
Compound 3: middle estimate off by 1.5-fold (0.17 log units), on the low side; measured number inside the range.
By their numbers in this assay, from the lowest: compound 2; then compound 3; then compound 1.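

In this assay, among the compounds shown here, replacing 2-carboxyethyl with 2-hydroxyethoxy on this aromatic carbon, para to a large group, gives a 9.6-fold higher number from compound 2 to compound 3 (0.98 log units; beyond the scatter) and is the first one-place change read. The carboxylic acid is therefore not required for a measurable response at this position, as compound 3 still gives 164 nM, but the change carries a cost beyond the scatter. Nothing available explains the size of this step.

As far as these compounds go, whether the step follows from the loss of the carboxylic acid or from the new ether oxygen remains open. A 3-hydroxypropyl chain or a 2-carboxyethoxy group at the same position would separate the two.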